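A few compounds are considered here, and "the series" means these few. Any claim that something is new, unique, unknown or untested is made for them only; others in the source may bear on it.

Measured in a functional assay on MCF7 cells (Homo sapiens) for antiproliferative activity, read by sulforhodamine B assay, with a stated time of 48 h; on this read-out lower numbers stand for stronger inhibition and higher numbers for weaker inhibition:

- compound 1 `Cc1ccc(NS(=O)(=O)c2ccc(N3CCNC3=O)cc2)cc1C`: 230 nM
- compound 2 `O=C1NCCN1c1ccc(S(=O)(=O)Nc2ccc(F)c(F)c2)cc1`: 620 nM
- compound 3 `Cc1cccc(NS(=O)(=O)c2ccc(N3CCNC3=O)cc2)c1C`: 230 nM

Compound 3 stands level with compound 1 at the digits shown, and the number they share is lower than that of compound 2. The next compound, compound 4 `Cc1ccccc1NS(=O)(=O)c1ccc(N2CCNC2=O)cc1`, differs from compound 3 by one change: hydrogen in place of methyl on an aromatic carbon. In words, hydrogen sits in place of methyl on an aromatic carbon, so 2,3-dimethylphenyl becomes 2-methylphenyl.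

Among the compounds with values here, no measured step removes a methyl group outright, so the evidence is indirect. All three measured steps alter the same aryl group on the sulfonamide nitrogen. Rearranging the methyl groups made no difference, seen in no change at the digits printed from compound 1 to compound 3 (within the scatter). Exchanging the dimethylphenyl groups for 3,4-difluorophenyl had only a modest effect, seen in a 2.7-fold higher number from compound 1 to compound 2 (0.43 log units; beyond the scatter) and in a 2.7-fold lower number from compound 2 to compound 3 (0.43 log units; beyond the scatter). Changes at this group have therefore moved this assay little so far, and a step larger than these modest ones is not expected. A small rise in the number is expected, though the direction is uncertain, and it may not clear the scatter. The estimated step is a 1.4-fold higher number from compound 3 to compound 4 (0.14 log units; within the scatter). For compound 4 the expected value is 320 nM, with an estimated range from 130 nM to 800 nM.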

Compound 4, half-maximal inhibitory concentration: 280 nM
Compound 4: middle estimate off by 1.1-fold (0.06 log units), on the high side; the range from low to high includes it.
By their numbers in this assay, from the lowest: compounds 1, 3 and 4 (each within the scatter of the next); then compound 2.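

In this assay, within the data shown here, this is the first step that takes a methyl group away outright rather than moving or exchanging substituents, and hydrogen in place of methyl on this aromatic carbon gives a 1.2-fold higher number from compound 3 to compound 4 (0.09 log units; within the scatter). The 2-methylphenyl compound also stands within the scatter of the 3,4-dimethylphenyl compound, with a 1.2-fold higher number from compound 1 to compound 4 (0.09 log units; within the scatter), while the gap to the 3,4-difluorophenyl compound persists, with a 2.2-fold lower number from compound 2 to compound 4 (0.35 log units; beyond the scatter), so a single methyl group, as in compound 4, and two, as in compound 1 and compound 3, give numbers that cannot be told apart, and only compound 2 stands off from that level. Nothing available on these compounds offers an explanation for this result.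

The compounds shown leave open whether the aryl group on the sulfonamide nitrogen needs any methyl group at all, and how a methoxy group, an amine or a carboxylic acid on that ring would read in this assay. On these data alone, all four also share the same core, so the effect of a change there remains unknown.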